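Fluoro Substitution on a Piperidine Analogue: Expected Cytotoxicity

This account rests on a few compounds, and the source may have more. Where it says the series, first, only, none or still open, it means among the compounds named here.

Compound 1 `COc1cc2c(Oc3ccc(NC(=O)c4nn(-c5ccccc5)c(=O)c5ccccc45)cc3F)ccnc2cc1OCCCN1CCN(C)CC1` and compound 3 `COc1cc2c(Oc3ccc(NC(=O)c4nn(-c5ccccc5)c(=O)c5ccccc45)cc3F)ccnc2cc1OCCCN1CCCCC1` share most of their structure; the difference between their cores is piperidin-1-yl in place of 4-methylpiperazin-1-yl on a saturated chain carbon, three bonds along the chain from an oxygen on an aromatic ring. In a functional assay on HT-29 cells (Homo sapiens) for cytotoxicity, read by MTT assay, with a stated time of 72 h (a higher number here means a weaker inhibitor, a lower number a stronger inhibitor), compound 1 gives 1140 nM, and compound 3 gives 1310 nM, a step of a 1.1-fold higher number from compound 1 to compound 3 (0.06 log units; within the scatter). Compound 2 `COc1cc2c(Oc3ccc(NC(=O)c4nn(-c5ccccc5F)c(=O)c5ccccc45)cc3F)ccnc2cc1OCCCN1CCN(C)CC1` carries one change from compound 1, (fluoro in place of hydrogen on an aromatic carbon), and in this assay compound 2 gives 480 nM; the step is a 2.4-fold lower number from compound 1 to compound 2 (0.38 log units; beyond the scatter). Compound 4 `COc1cc2c(Oc3ccc(NC(=O)c4nn(-c5ccccc5F)c(=O)c5ccccc45)cc3F)ccnc2cc1OCCCN1CCCCC1` has not yet been measured; it differs from compound 3 by fluoro in place of hydrogen on an aromatic carbon, the same change, at the same place on the same ring, that turns compound 1 into compound 2. Among the compounds with values here, since the cores of compound 1 and compound 3 behave alike in this assay, as the step of a 1.1-fold higher number from compound 1 to compound 3 (0.06 log units; within the scatter) shows, the one precedent for this change is the step of a 2.4-fold lower number from compound 1 to compound 2 (0.38 log units; beyond the scatter), and compound 4 is expected to move by about as much, a 2.2-fold lower number from compound 3 to compound 4 (0.34 log units; beyond the scatter). Within the data shown here, with only a single earlier example of the change to rest on, the expected result for compound 4 in this assay is 600 nM, with a likely range from 300 nM to 1200 nM.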

Compound 4, half-maximal inhibitory concentration: 630 nM
Compound 4: the middle estimate sits 1.1-fold (0.02 log units) below what was measured; the range from low to high includes it.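

In this assay, the change from phenyl to 2-fluorophenyl on the core of compound 3 gives a 2.1-fold lower number from compound 3 to compound 4 (0.32 log units; beyond the scatter), and this step matches the one seen earlier on the core of compound 1: the same change on two cores in this assay, a 2.4-fold lower number (0.38 log units; beyond the scatter) from compound 1 to compound 2 and a 2.1-fold lower number (0.32 log units; beyond the scatter) from compound 3 to compound 4, 1.1-fold (0.06 log units) apart, within the scatter of two such steps. The exchange of the ring at the end of the chain, read this time among the fluoro compounds as a 1.3-fold higher number from compound 2 to compound 4 (0.12 log units; within the scatter), agrees in the same way: the same change on two cores in this assay, a 1.1-fold higher number (0.06 log units; within the scatter) from compound 1 to compound 3 and a 1.3-fold higher number (0.12 log units; within the scatter) from compound 2 to compound 4, 1.1-fold (0.06 log units) apart, within the scatter of two such steps. Within these four compounds, the fluoro change therefore carries from one core to the other with no difference beyond the scatter, but this rests on only two cores that differ solely in that end group, so it neither establishes transfer to other cores nor explains why the number falls.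

The compounds shown leave open whether chloro or methyl in place of the fluoro would give a step of similar size. They also leave open whether the step would hold with a morpholin-4-yl group or a longer chain at the other end of the molecule.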